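The compounds below may be only part of what the source reports. "The series", "measured", "known", "first", "only" and "open" are said of these compounds alone.

Compound 1 `COc1cc(-c2cc(/C=C/C(=O)c3ccc(N)cc3)[nH]n2)cc(OC)c1OC` and compound 2 `COc1ccc(-c2cc(/C=C/C(=O)c3ccc(N)cc3)[nH]n2)cc1OC` share a core and differ in one place. In a functional assay on HCC 2998 cells (Homo sapiens) for inhibition, read by sulforhodamine B assay, with a stated time of 48 h (a lower number here means a stronger inhibitor of growth, a higher number a weaker inhibitor of growth), compound 1 gives 3630 nM, and in this assay compound 2 gives 3830 nM. The change between them is hydrogen in place of methoxy on an aromatic carbon and it made a step of a 1.1-fold higher number from compound 1 to compound 2 (0.02 log units; within the scatter).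

Compound 3 `COc1cc(C(=O)/C=C/c2cc(-c3cc(OC)c(OC)c(OC)c3)n[nH]2)cc(OC)c1OC` is built on a different core; how the two cores differ is not broken down here. In this assay compound 3 gives 3390 nM, a number that sits close to those of compound 1 and compound 2, within the usual scatter of such measurements.

Compound 4 `COc1ccc(-c2cc(/C=C/C(=O)c3cc(OC)c(OC)c(OC)c3)[nH]n2)cc1OC` has not yet been measured. It is made from compound 3 by the same change already seen between compound 1 and compound 2: hydrogen in place of methoxy on an aromatic carbon. Because the earlier step was a 1.1-fold higher number from compound 1 to compound 2 (0.02 log units; within the scatter), the step from compound 3 to compound 4 in this assay is expected to be small as well, about a 1.1-fold higher number from compound 3 to compound 4 (0.04 log units; within the scatter). On that basis compound 4 is estimated to give 3700 nM, with a likely range from 1800 nM to 7500 nM.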

Compound 4, concentration for total growth inhibition: 3400 nM
Beside the measured number, compound 4's estimate is 1.1-fold (0.04 log units) above it, within the range that was stated.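

In this assay, putting hydrogen in place of methoxy on an aromatic carbon gives a 1.0-fold higher number from compound 3 to compound 4 (0.00 log units; within the scatter), so on this second core the two numbers again lie within the usual scatter, and the two steps agree: the same change on two cores in this assay, a 1.1-fold higher number (0.02 log units; within the scatter) from compound 1 to compound 2 and a 1.0-fold higher number (0.00 log units; within the scatter) from compound 3 to compound 4, 1.1-fold (0.02 log units) apart, within the scatter of two such steps

This shows that, for these two pairs, the change carries from one core to the other in a simple way: it makes no readable difference on either. It does not show that the result would hold on further cores or in other kinds of test, and two flat steps cannot reveal how a larger effect would carry over, since neither pair has one to compare.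

The compounds shown offer only methoxy or hydrogen at this place, so the effect of a carboxylic acid or a longer chain such as butoxy there remains open. Also open, on these data alone, is whether removing a second methoxy group from the same ring would stay just as silent.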